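Propylcarbonyl ester of compound 1: expected whole-animal dose

The compounds below may be only part of what the source reports. "The series", "measured", "known", "first", "only" and "open" are said of these compounds alone.

Compound 1 `OC1CCN(c2ccc(-c3ccc(Cl)cc3Cl)nn2)CC1` gives 8.5 mg/kg in a functional assay on the whole organism with Mus musculus as the target; on this read-out lower numbers stand for an effect already at smaller amounts and higher numbers for an effect only at larger amounts of compound. Among the three measured values compound 1 stands second highest. Its nearest neighbour is compound 3 `O=C1CCN(c2ccc(-c3ccc(Cl)cc3Cl)nn2)CC1`, which in this assay gives 7.3 mg/kg; the furthest is compound 2 `Cc1ccc(-c2ccc(N3CCC(O)CC3)nn2)c(Cl)c1`, which in this assay gives 17 mg/kg. The step of a 1.2-fold lower number from compound 1 to compound 3 (0.07 log units; within the scatter) and the step of a 2.0-fold higher number from compound 1 to compound 2 (0.30 log units; within the scatter) both stay within the scatter, so no order can be read among these three compounds.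

Compound 4 `CCCC(=O)OC1CCN(c2ccc(-c3ccc(Cl)cc3Cl)nn2)CC1` differs from compound 1 by propylcarbonyl in place of hydrogen on an oxygen on a saturated carbon. Of the measured steps, only a 1.2-fold lower number from compound 1 to compound 3 (0.07 log units; within the scatter) alters the same hydroxy group, and it left the number within the scatter; the step of a 2.0-fold higher number from compound 1 to compound 2 (0.30 log units; within the scatter) concerns an aromatic carbon elsewhere on the core and was likewise within the scatter. On this basis no step beyond the scatter is expected in this assay for compound 4, in either direction. The expected step is a 1.1-fold higher number from compound 1 to compound 4 (0.02 log units; within the scatter). The estimate for compound 4 in this assay is 9 mg/kg, with a range from 4 mg/kg to 20 mg/kg.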

Compound 4, dose for half-maximal effect: 31 mg/kg
The estimate for compound 4 lay 3.4-fold (0.54 log units) below the measured number, and the stated range ends below it.
By their numbers in this assay, from the lowest: compounds 3, 1, 2 and 4 (each within the scatter of the next, the first and the last beyond it).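

Among the compounds shown here, putting propylcarbonyl on the oxygen of the hydroxy group gives the first step beyond the scatter in this assay, with a 3.6-fold higher number from compound 1 to compound 4 (0.56 log units; beyond the scatter), though the step is modest. This position therefore does respond to change, which the earlier step at the same hydroxy group, a 1.2-fold lower number from compound 1 to compound 3 (0.07 log units; within the scatter), did not show: the 4-oxopiperidin-1-yl group stays within the scatter, whereas the (propylcarbonyl)oxy group does not. Nothing available bears on the reason for this step.

Open, from the compounds shown here alone, is whether the step belongs to the ester link or to the length of the chain. An acetyl ester, a longer acyl chain, a methyl ether or an amine on the same saturated carbon could separate these readings, since each would either stay with compound 1 or move with compound 4.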